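The source may hold more compounds than are shown below. What is called first, only, known or untested is meant among the compounds shown, and "the series" means these compounds.

Measured in a functional assay on DU-145 cells (Homo sapiens) for cytotoxicity, read by trypan blue exclusion, with a stated time of 96 h; on this read-out lower numbers stand for stronger inhibition and higher numbers for weaker inhibition:
- compound 1 `COc1ccccc1/C=C/S(=O)(=O)Cc1ccc(OC)c([N+](=O)[O-])c1`: 20000 nM
- compound 2 `COc1ccc(CS(=O)(=O)/C=C/c2cc(F)c(F)cc2F)cc1N`: 5000 nM

Compound 1 holds the higher of the two numbers, and the gap down to compound 2 lies beyond the scatter. Compound 3 `COc1ccc(CS(=O)(=O)/C=C/c2ccccc2OC)cc1N`, not yet measured, differs from compound 1 in one place: amino in place of nitro on an aromatic carbon, ortho to a methoxy group (amino in place of nitro on an aromatic carbon). Among the compounds with values here, no measured pair isolates this change. Compound 2 also carries the amino, with other substituents elsewhere, and gives 5000 nM, so a lower number is expected in this assay. The expected step is a 5.0-fold lower number from compound 1 to compound 3 (0.70 log units; beyond the scatter). The estimate for compound 3 is 4000 nM, with a range of 800 nM to 15000 nM.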

Compound 3, half-maximal inhibitory concentration: 7500 nM
The estimate for compound 3 lay 1.9-fold (0.27 log units) below the measured number; low and high end bracket the measured number.
By their numbers in this assay, from the lowest: compounds 2 and 3 (each within the scatter of the next); then compound 1.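

With a direct pair now in hand, amino in place of nitro on this aromatic carbon, ortho to a methoxy group, gives a 2.7-fold lower number from compound 1 to compound 3 (0.43 log units; beyond the scatter) in this assay as a modest change beyond the scatter. The direction of the change at this position therefore no longer rests on a compound with other substituents elsewhere. No measured evidence bears on what lies behind the step.

From the compounds shown here alone, whether an acetamide or a hydroxyl group on the same carbon would lower the number further remains open. So does whether the step holds with other substituents elsewhere on the core.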